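Compound 3 to compound 4: a new group on the shared core

The compounds below may be only part of what the source reports. "The series", "measured", "known", "first", "only" and "open" are said of these compounds alone.

In a toxicity assay on HepG2 2.2.15 cells (Homo sapiens) for cytotoxicity, read by CellTiter-Glo (on this read-out lower numbers stand for higher toxicity in this test and higher numbers for lower toxicity in this test), compound 2 (`O=C1NC(c2ccccc2)CN1c1cnn2c1CN(C(=O)Nc1cc(F)c(F)c(F)c1)C(C1CC1)C2`) gives 38500 nM and compound 3 (`O=C1c2ccccc2CN1c1cnn2c1CN(C(=O)Nc1cc(F)c(F)c(F)c1)C(C1CC1)C2`) gives 38500 nM, so compound 3 stands level with compound 2. Compound 1 (`O=C1CC(Oc2ncccn2)CN1c1cnn2c1CN(C(=O)Nc1cc(F)c(F)c(F)c1)C(C1CC1)C2`) reads > 200000 nM, which is a limit of the assay and not a number.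

The change to compound 4 (`Cc1nc(C2CC(=O)N(c3cnn4c3CN(C(=O)Nc3cc(F)c(F)c(F)c3)C(C3CC3)C4)C2)no1`) is a group of 12 heavy atoms (7 carbon, 3 nitrogen, 2 oxygen; one five-membered non-aromatic ring with 1 hetero atom, one five-membered aromatic ring with 3 hetero atoms) in place of a group of 10 heavy atoms (8 carbon, 1 nitrogen, 1 oxygen; one five-membered non-aromatic ring with 1 hetero atom, one six-membered aromatic ring of carbon only), on an aromatic carbon. The entering group is 4-(5-methyl-1,2,4-oxadiazol-3-yl)-2-oxopyrrolidin-1-yl.

For the measured compounds named here, the only measured step that bears on this is no change at the digits printed from compound 2 to compound 3 (within the scatter), which also exchanged one group for another on an aromatic carbon. It suggests that this assay tolerates such exchanges, but it is a single case. The limit held by compound 1 gives a weak lean toward higher numbers, which would mean lower toxicity in this test.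

The expected change is modest, a 1.8-fold higher number from compound 3 to compound 4 (0.26 log units; within the scatter). Compound 4 is estimated at 70000 nM, with an expected range of 30000 nM to 200000 nM.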

Compound 4, half-maximal cytotoxic concentration: > 200000 nM
Compound 4 was reported as a limit (the forecaster's own chance of this, stated with the estimate: 30%); middle value at least 2.8-fold (0.45 log units) from the limit.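

In this assay this position on the five-membered aromatic ring now gives a step beyond the scatter: an at least 5.1-fold higher number from compound 3 to compound 4 (0.71 log units; beyond the scatter) and also an at least 5.1-fold higher number from compound 2 to compound 4 (0.71 log units; beyond the scatter). The earlier exchange showed no such separation, with no change at the digits printed from compound 2 to compound 3 (within the scatter). So the entering group 4-(5-methyl-1,2,4-oxadiazol-3-yl)-2-oxopyrrolidin-1-yl moves the number toward lower toxicity in this test relative to both groups it was compared with, although the result for compound 4 is a limit of the assay and not a number, so only a minimum size can be read: the limit of > 200000 nM in this assay, at which 2 of the 4 values shown sit.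

The step between compound 1 and compound 4 cannot be read, as both values are limits. Open, from the compounds shown here alone, is whether an amine or a carboxylic acid in place of 5-methyl-1,2,4-oxadiazol-3-yl would keep the number this high.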